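The source may report more compounds than this note shows. Statements on the series, on what has been measured and on what is new or still open speak of the compounds shown alone.

Compound 1 `O=C(O)c1cc2c(F)c(O)ccc2n1Cc1ccc(Cl)c(Cl)c1` gives 19300 nM
Compound 2 `CC(=O)Oc1ccc2c(c1)cc(C(=O)O)n2Cc1ccc(Cl)c(Cl)c1` gives 55200 nM
Compound 3 `COc1c(C(=O)O)n(Cc2ccc(Cl)c(Cl)c2)c2ccc(O)cc12` gives 39600 nM

All three numbers come from an ADME assay for inhibition of Bile salt export pump (Homo sapiens), read by scintillation counting, with a stated time of 5 min; on this read-out lower numbers stand for stronger inhibition and higher numbers for weaker inhibition. Compound 3 stands second highest of the three; compound 2 lies within the scatter of it, while compound 1 shows a lower number, a gap beyond the scatter. Compound 4 `O=C(O)c1cc2cc(O)ccc2n1Cc1ccc(Cl)c(Cl)c1` has not yet been measured in this assay. It differs from compound 3 by hydrogen in place of methoxy on an aromatic carbon. Going by the values given here, no pair of measured compounds differing in one place is available, so the size of such a step cannot be read from the data. With all three numbers lying close together, the change is expected to stay within the scatter, in no clear direction. The resulting step is expected to be a 1.3-fold lower number from compound 3 to compound 4 (0.12 log units; within the scatter). Compound 4 is estimated at 30000 nM, between 12000 nM and 80000 nM.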

Compound 4, half-maximal inhibitory concentration: 49800 nM
Beside the measured number, compound 4's estimate is 1.7-fold (0.22 log units) below it; low and high end bracket the measured number.
By their numbers in this assay, from the lowest: compound 1; then compounds 3, 4 and 2 (each within the scatter of the next).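

In this assay, this assay, hydrogen and methoxy on this aromatic carbon of the five-membered ring cannot be told apart (a 1.3-fold higher number from compound 3 to compound 4 (0.10 log units; within the scatter)). The same holds for hydrogen and acetyl on the oxygen (a 1.1-fold lower number from compound 2 to compound 4 (0.04 log units; within the scatter)), while only the change from fluoro to hydrogen goes beyond the scatter, and modestly (a 2.6-fold higher number from compound 1 to compound 4 (0.41 log units; beyond the scatter)). No evidence available here bears on these steps. From the compounds shown here alone, whether an amine, a nitrile or a longer alkoxy chain on the carbon that held the methoxy group would shift the number remains open. So does the effect of an amide in place of the carboxy group.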